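Bromo to phenyl on the aryl ring of compound 2

The source may report more compounds than this note shows. Statements on the series, on what has been measured and on what is new or still open speak of the compounds shown alone.

Compound 2 `N=C(N)Nc1cccc(C(=O)NNC(=O)CC(CC(=O)O)c2ccc(Br)cc2)c1` gives 1.95 in a physicochemical assay for lipophilicity (a lower number here means a more polar compound, a higher number a more lipophilic compound), and stands second highest of the three measured values. Compound 1 `N=C(N)Nc1cccc(C(=O)NNC(=O)CC(CC(=O)O)c2ccc(F)cc2)c1` gives 1.28 in this assay, and compound 3 `N=C(N)Nc1cccc(C(=O)NNC(=O)CC(CC(=O)O)c2cc(Cl)cc(Cl)c2)c1` gives 2.24. The measured steps are a number 0.67 log units higher from compound 1 to compound 2 (beyond the scatter), a number 0.96 log units higher from compound 1 to compound 3 (beyond the scatter) and a number 0.29 log units higher from compound 2 to compound 3 (within the scatter); the first two are modest rises beyond the scatter, the third lies within it.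

Compound 4 `N=C(N)Nc1cccc(C(=O)NNC(=O)CC(CC(=O)O)c2ccc(-c3ccccc3)cc2)c1` differs from compound 2 by phenyl in place of bromo on an aromatic carbon. Within the data shown here, no measured step replaces a halogen by a phenyl group, so the expectation rests on extrapolation: the exchange of fluoro for bromo and the exchange of 4-fluorophenyl for 3,5-dichlorophenyl each raised this assay, and the phenyl group brings six carbon atoms where a single bromine stood. A rise larger than the measured steps is therefore expected, with the step from compound 2 to compound 4 estimated at a number 1.05 log units higher from compound 2 to compound 4 (beyond the scatter). For compound 4 the estimate in this assay is 3, with a range from 2.5 to 3.5.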

Compound 4, partition coefficient: 2.8
Beside the measured number, compound 4's estimate is 0.20 log units above it; the range from low to high includes it.
By their numbers in this assay, from the lowest: compound 1; then compounds 2 and 3 (each within the scatter of the next); then compound 4.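

In this assay, phenyl in place of bromo on this aromatic carbon gives a number 0.85 log units higher from compound 2 to compound 4 (beyond the scatter), so the rise seen among the halogens continues when a whole six-membered aromatic ring of carbon only enters at this position, para to a large group. Phenyl in place of fluoro at the same carbon gives a number 1.52 log units higher from compound 1 to compound 4 (beyond the scatter), the first large step in the series; the earlier steps were modest or within the scatter. Nothing on hand bears on what lies behind these rises.

The compounds shown leave open whether the step follows the ring itself or only the added carbon atoms, a question that a saturated hexyl chain at the same carbon would address. Also open, from the compounds shown here alone, is how a phenyl group carrying an amine or a carboxylic acid would read in this assay.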